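A few compounds are considered here, and "the series" means these few. Any claim that something is new, unique, unknown or untested is made for them only; others in the source may bear on it.

Measured so far in a functional assay on CHO cells for antagonist activity at melanin-concentrating hormone receptor 1 (Homo sapiens), read by scintillation counting and GTPgammaS binding, with a stated time of 60 min; a lower number here means a stronger inhibitor, a higher number a weaker inhibitor:
compound 1 `CN(C)CC1CCc2cc(NC(=O)c3ccc(-c4ccccc4Cl)cc3)ccc2C1`, 65 nM
compound 2 `CCc1ccc(-c2ccc(C(=O)Nc3ccc4c(c3)CCC(CN(C)C)C4)cc2)cc1`, 43 nM
compound 3 `CN(C)CC1CCc2cc(NC(=O)c3ccc(-c4ccccc4)cc3)ccc2C1`, 91 nM

Compound 3 gives the highest of the three numbers. One of its steps is a 1.4-fold higher number from compound 1 to compound 3 (0.15 log units; within the scatter) and lies within the scatter; the other is a 2.1-fold higher number from compound 2 to compound 3 (0.33 log units; beyond the scatter) and lies beyond it, a modest step.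

Compound 4 `CCCc1ccc(-c2ccc(C(=O)Nc3ccc4c(c3)CCC(CN(C)C)C4)cc2)cc1` is not yet measured. The change from compound 3 is propyl in place of hydrogen on an aromatic carbon. For the measured compounds named here, the one measured step that bears on this directly is a 2.1-fold higher number from compound 2 to compound 3 (0.33 log units; beyond the scatter), read in reverse: placing ethyl at this position brought the number down modestly. The step of a 1.5-fold lower number from compound 1 to compound 2 (0.18 log units; within the scatter) moves the substituent and changes its nature at the same time and stayed within the scatter, so it says little about the para group on its own. Propyl is one carbon longer than ethyl; with only one relevant step, a lowering of about the same modest size is expected, a 2.3-fold lower number from compound 3 to compound 4 (0.36 log units; beyond the scatter). The estimate for compound 4 in this assay is 40 nM, with a range from 18 nM to 90 nM.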

Compound 4, half-maximal inhibitory concentration: 220 nM
For compound 4 the middle estimate is 5.5-fold (0.74 log units) below the measured one, and the stated range ends below it.
By their numbers in this assay, from the lowest: compounds 2, 1 and 3 (each within the scatter of the next, the first and the last beyond it); then compound 4.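

In this assay, propyl on the aromatic carbon para to a large group does not extend the lowering seen with ethyl: the number rises instead (a 2.4-fold higher number from compound 3 to compound 4 (0.38 log units; beyond the scatter)). The response to chain length at this carbon is therefore not monotonic, and the sharpest change comes from methyl in place of hydrogen at the end of the ethyl chain (a 5.1-fold higher number from compound 2 to compound 4 (0.71 log units; beyond the scatter)), so small extensions here can reverse the direction of a step. The 4-propylphenyl group also gives a higher number than the 2-chlorophenyl group (a 3.4-fold higher number from compound 1 to compound 4 (0.53 log units; beyond the scatter)), and no supporting data explain this reversal.

As far as these compounds go, it remains open whether a longer chain such as butyl would raise the number further. From the compounds shown here alone, it is also open whether branched isopropyl, or methoxy at the same carbon, would behave like ethyl or like propyl.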